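Changing the sulfonyl aryl group on compound 1

A few compounds are considered here, and "the series" means these few. Any claim that something is new, unique, unknown or untested is made for them only; others in the source may bear on it.

In a functional assay on A2780 cells (Homo sapiens) for inhibition, read by sulforhodamine B assay, with a stated time of 72 h (on this read-out lower numbers stand for stronger inhibition and higher numbers for weaker inhibition), compound 1 `O=C(NCc1ccc(S(=O)(=O)c2cccc(C(F)(F)F)c2)cc1)c1cc2cnccc2[nH]1` gives 3 nM. Compound 2 `O=C(NCc1ccc(S(=O)(=O)c2cccc(C(F)(F)F)c2)cc1)c1cc2ccncc2o1` gives 3 nM, level with compound 1. Compound 3 `O=C(NCc1ccc(S(=O)(=O)c2cccc(C(F)(F)F)c2)cc1)c1cc2ccncc2s1` gives 1 nM, the lowest number of the three. Compound 4 `O=C(NCc1ccc(S(=O)(=O)c2ccc(F)cc2)cc1)c1cc2cnccc2[nH]1` keeps the core of compound 1 and differs on the sulfonyl sulfur: 4-fluorophenyl in place of 3-(trifluoromethyl)phenyl on a sulfonyl sulfur. The measured steps alter only the core: no change at the digits printed from compound 1 to compound 2 (within the scatter), and a 3.0-fold lower number from compound 2 to compound 3 (0.48 log units; beyond the scatter). For the measured compounds named here, no measured step changes the sulfonyl aryl group, so they offer only a rough scale. On that scale, a 3.0-fold lower number from compound 1 to compound 3 (0.48 log units; beyond the scatter) suggests a modest step at most, with a somewhat higher number the tentative direction. The expected step is a 1.7-fold higher number from compound 1 to compound 4 (0.22 log units; within the scatter). For compound 4 the estimated value is 5 nM, within a range of 1.5 nM to 20 nM.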

Compound 4, half-maximal inhibitory concentration: 16 nM
The estimate for compound 4 lay 3.2-fold (0.51 log units) below the measured number; measured number inside the range.
By their numbers in this assay, from the lowest: compound 3; then compounds 1 and 2 (each within the scatter of the next); then compound 4.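

For the compounds shown here, the sulfonyl aryl group is not a silent position: with the core held constant, a 5.3-fold higher number from compound 1 to compound 4 (0.73 log units; beyond the scatter), the first measured step at this place. Within this pair, 3-(trifluoromethyl)phenyl gives the lower number, but the single step changes both the substituent and its placing, so neither can be credited alone. Nothing available accounts for the step.

Open, on these data alone, is how unsubstituted phenyl or 4-(trifluoromethyl)phenyl would read on the sulfonyl sulfur. Also open, as far as these compounds go, is whether 4-fluorophenyl would produce a similar step on the cores of compound 2 and compound 3.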